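The source may hold more compounds than are shown below. What is called first, only, known or untested is meant among the compounds shown, and "the series" means these compounds.

Measured compounds:
Compound 1 `Cc1cc(NC(=O)Cn2nnc(-c3ccccc3)n2)n(C2CCCCC2)n1` gives 96 nM in an assay on HEK293 cells for activation of Kir3.1/Kir3.2 (Homo sapiens), read by thallium flux; a lower number here means that less compound is needed, a higher number that more compound is needed for the effect.
Compound 2 `Cc1cc(NC(=O)Cn2nnc(-c3ccccc3)n2)n(C2CCS(=O)(=O)C2)n1` gives 1030 nM in this assay.
Compound 3 `Cc1cc(NC(=O)Cn2nnc(-c3ccccc3)n2)n(C2CCS(=O)(=O)CC2)n1` gives > 10000 nM in this assay, which is a limit of the assay and not a number.

Compound 3 therefore stands at the limit of > 10000 nM in this assay, at which 1 of the 3 values shown sits; it has no measured number, only a limit. The unmeasured compound 4 `Cc1cc(NC(=O)Cn2nnc(-c3ccccc3)n2)n(-c2ccccc2)n1` differs from it in one place: phenyl in place of 1,1-dioxothian-4-yl on an aromatic nitrogen. Among the compounds with values here, two measured steps bear on this change, both leading to compound 3. The step of an at least 100-fold higher number from compound 1 to compound 3 (2.01 log units; beyond the scatter) shows that swapping cyclohexyl for 1,1-dioxothian-4-yl pushed the value beyond the limit, and the step of an at least 9.7-fold higher number from compound 2 to compound 3 (0.98 log units; beyond the scatter) points the same way. Phenyl, like cyclohexyl, is a six-membered ring of carbon only with no hydrogen-bond acceptors, so the change from compound 3 to compound 4 undoes much of what the step from compound 1 to compound 3 did. Compound 4 is therefore expected to give 300 nM, with a range of 60 nM to 3000 nM. The expected step is an at least 33-fold lower number from compound 3 to compound 4 (1.52 log units; beyond the scatter).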

Compound 4, half-maximal effective concentration: 3020 nM
Estimate against measurement, compound 4: 10-fold (1.00 log units) below, and the stated range ends below it.
By their numbers in this assay, from the lowest: compound 1; then compound 2; then compound 4. At a limit, above all of these: compound 3.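

In this assay, swapping one carbon-only six-membered ring for another on this aromatic nitrogen is far from neutral, with a 31-fold higher number from compound 1 to compound 4 (1.50 log units; beyond the scatter), and phenyl also does worse than a ring holding sulfur, with a 2.9-fold higher number from compound 2 to compound 4 (0.47 log units; beyond the scatter). So a ring of carbon only does not by itself keep the number low, and whether that ring is aromatic matters at this position. Phenyl still improves on 1,1-dioxothian-4-yl, with an at least 3.3-fold lower number from compound 3 to compound 4 (0.51 log units; beyond the scatter), though compound 3 sets only a limit of the assay and not a number: the limit of > 10000 nM in this assay, at which 1 of the 4 values shown sits.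

From the compounds shown here alone, it remains open whether a cyclopentyl or a tert-butyl group on this nitrogen would keep the number close to that of compound 1. Going by these compounds, it is also open whether a fluorine on the phenyl, or a pyridine ring in its place, would lower the number of compound 4.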